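A few compounds are considered here, and "the series" means these few. Any claim that something is new, unique, unknown or untested is made for them only; others in the source may bear on it.

Compounds 1 to 3 share one core and differ only in a 4-fluorophenyl, 2,4-dichlorophenyl or 4-hydroxyphenyl group. In a functional assay on MCF7 cells (Homo sapiens) (on this read-out lower numbers stand for stronger inhibition of growth and higher numbers for weaker inhibition of growth), compound 1 `O=S(=O)(/C=C/c1ccc(F)cc1)Cc1ccc(Nc2ncnc3ccccc23)cc1` gives 16000 nM, compound 2 `O=S(=O)(/C=C/c1ccc(Cl)cc1Cl)Cc1ccc(Nc2ncnc3ccccc23)cc1` gives 4000 nM and compound 3 `O=S(=O)(/C=C/c1ccc(O)cc1)Cc1ccc(Nc2ncnc3ccccc23)cc1` gives 100000 nM. Compound 3 therefore has the highest number of the three and is the weakest growth inhibitor among them.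

Compound 4 `O=S(=O)(/C=C/c1ccc(O)cc1)Cc1ccc(Nc2ncnc3ccc(Br)cc23)cc1` makes one change to compound 3: bromo in place of hydrogen on an aromatic carbon. For the measured compounds named here, no measured step involves this carbon, so the evidence is only indirect. The closest guides are the changes elsewhere in the molecule: a 6.3-fold higher number from compound 1 to compound 3 (0.80 log units; beyond the scatter) and a 25-fold higher number from compound 2 to compound 3 (1.40 log units; beyond the scatter). Together with a 4.0-fold lower number from compound 1 to compound 2 (0.60 log units; beyond the scatter), they show that both halogen-bearing compounds have lower numbers than the hydroxy compound, with no compound here going against this. These steps come from another part of the structure, so only a modest gain is expected, and no change beyond the scatter remains possible. The expected change is a 3.3-fold lower number from compound 3 to compound 4 (0.52 log units; beyond the scatter). In this assay, the estimated value for compound 4 is 30000 nM, within an expected range of 6000 nM to 120000 nM.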

Compound 4, concentration for 50% growth inhibition: 32000 nM
Beside the measured number, compound 4's estimate is 1.1-fold (0.03 log units) below it, and the stated range covers the measured number.
By their numbers in this assay, from the lowest: compound 2; then compounds 1 and 4 (each within the scatter of the next); then compound 3.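

Putting bromo in place of hydrogen on an aromatic carbon of the fused system of two rings gives a 3.1-fold lower number from compound 3 to compound 4 (0.49 log units; beyond the scatter) in this assay. For the compounds shown here, the earlier steps changed only the aryl group on the double-bonded chain, so this is the first sign that this part of the structure also affects the read-out. A single bromine atom here is enough to move the number beyond the usual scatter, though nothing available explains the change.

Among the compounds shown, bromo appears only with the 4-hydroxyphenyl group, so whether the step would be similar with the 4-fluorophenyl or 2,4-dichlorophenyl group remains open. Going by these compounds, it is also open how chloro, methoxy or an amine on this same carbon would compare with bromo.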